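Adding one fluoro group to compound 2

The source may hold more compounds than are shown below. What is called first, only, known or untested is meant among the compounds shown, and "the series" means these compounds.

In a functional assay on HeLa cells (Homo sapiens) for cytotoxicity, read by MTT assay, with a stated time of 72 h (on this read-out higher numbers stand for weaker inhibition and lower numbers for stronger inhibition), compound 1 (`Cn1ccc2c(Oc3ccc(NC(=O)c4cc5cccnc5n(-c5ccc(F)cc5)c4=O)cc3F)ncnc21`) gives 4250 nM and compound 2 (`O=C(Nc1ccc(Oc2ncnc3[nH]ccc23)c(F)c1)c1cc2cccnc2n(-c2ccccc2)c1=O`) gives 36900 nM on the same read-out. Compound 2 holds the higher of these two numbers, with a gap beyond the scatter, which makes it the weaker of the pair.

Compound 3 (`O=C(Nc1ccc(Oc2ncnc3[nH]ccc23)c(F)c1)c1cc2cccnc2n(-c2ccc(F)cc2)c1=O`) has not yet been measured. It differs from compound 2 at one place, by fluoro in place of hydrogen on an aromatic carbon with fluoro in place of hydrogen on an aromatic carbon, para to a large group, so that phenyl becomes 4-fluorophenyl.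

For the measured compounds named here, no measured pair isolates this change, so the size of its step in this assay rests on thin support. Compound 1, which also carries a 4-fluorophenyl group, stands at 4250 nM on the stronger side, but one value is a weak guide. A modest move toward a lower number is expected, although a result within the scatter would be no surprise. The expected shift is a 2.5-fold lower number from compound 2 to compound 3 (0.39 log units; beyond the scatter) on this estimate. Compound 3 is estimated at 15000 nM with an expected range from 5000 nM to 40000 nM for now.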

Compound 3, half-maximal inhibitory concentration: 3720 nM
Estimate against measurement, compound 3: 4.0-fold (0.61 log units) above; measured number below the stated range.
By their numbers in this assay, from the lowest: compounds 3 and 1 (each within the scatter of the next); then compound 2.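

In this assay, for the compounds shown here, the first measured step at this position is the change from phenyl to 4-fluorophenyl, which gives a 9.9-fold lower number from compound 2 to compound 3 (1.00 log units; beyond the scatter) and shows that this one fluoro group, on an aromatic carbon para to a large group, moves the number well beyond the scatter. With the 4-fluorophenyl group held constant, the change of hydrogen in place of methyl on an aromatic nitrogen gives a 1.1-fold lower number from compound 1 to compound 3 (0.06 log units; within the scatter) and stays within the scatter, so in this pair that nitrogen substituent makes no measurable difference on this read-out. Nothing measured for these compounds accounts for the size of the fluoro step.

The compounds shown leave open whether chloro, methoxy or an amine on that same aromatic carbon would give a step of similar size, or whether the effect belongs to fluoro alone. Going by these compounds alone, they also leave open whether the fluoro step holds when methyl sits on the aromatic nitrogen, since the phenyl partner of compound 1 is not among them, and the single pair here cannot show how far the step carries to other members.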